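This account rests on a few compounds, and the source may have more. Where it says the series, first, only, none or still open, it means among the compounds named here.

The compounds were tested in a functional assay on A549 cells (Homo sapiens) for cytotoxicity, read by sulforhodamine B assay, with a stated time of 48 h; a higher number here means a weaker inhibitor, a lower number a stronger inhibitor.
Compound 1 `CCC(C)c1cc(/C=C/C(=O)c2ccccc2)cc2cc(C(=O)OC)c(=O)oc12` gives 10700 nM in this assay.
Compound 2 `CCOC(=O)c1cc2cc(/C=C/C(=O)c3ccc(C)cc3)cc(C(C)CC)c2oc1=O` gives 32800 nM in this assay.
Compound 3 `CCC(C)c1cc(C=O)cc2cc(C(C)=O)c(=O)oc12` was reported as "not active" (no number reported) in this assay, with no number given.

Among the two compounds with a number, compound 2 stands highest, and the gap to compound 1 lies beyond the scatter. Compound 4 `CCOC(=O)c1cc2cc(/C=C/C(=O)c3ccc(Cl)cc3)cc(C(C)CC)c2oc1=O` is the next compound, differing from compound 2 by chloro in place of methyl on an aromatic carbon. Among the measured compounds shown here, no pair of measured compounds shows this change, so its effect is unknown here. A small step is expected, possibly none beyond the scatter, with the direction uncertain. Compound 4 is therefore estimated at 25000 nM, within 8000 nM to 80000 nM, a step of a 1.3-fold lower number from compound 2 to compound 4 (0.12 log units; within the scatter) expected.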

Compound 4, half-maximal inhibitory concentration: 12900 nM
Beside the measured number, compound 4's estimate is 1.9-fold (0.29 log units) above it; measured number inside the range.
By their numbers in this assay, from the lowest: compounds 1 and 4 (each within the scatter of the next); then compound 2.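

In this assay, among the compounds shown here, chloro in place of methyl on the aromatic ring of the 4-methylphenyl group gives a 2.5-fold lower number from compound 2 to compound 4 (0.41 log units; beyond the scatter), the first change in a single place that can be read in this set. It shows that the number responds to swapping just one heavy atom at this position, a modest step but one that exceeds the usual scatter. Nothing measured here explains the step.

Going by these compounds, whether an amine, a methoxy group or a carboxylic acid at this position would lower the number further remains open. So does whether the same swap would give a similar step with the methyl ester of compound 1 in place of the ethyl ester.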